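The source may report more compounds than this note shows. Statements on the series, on what has been measured and on what is new or still open speak of the compounds shown alone.

Measured in a functional assay on HL-60 cells (Homo sapiens) for cytotoxicity, read by CellTiter-Blue, with a stated time of 48 h; on this read-out lower numbers stand for stronger inhibition and higher numbers for weaker inhibition:
- Compound 1 `CCCCOC(=O)CC1C(C(=O)OCCCC)=C(N)Oc2ccc(-c3cc(OC)cc(OC)c3)cc21`: 32000 nM
- Compound 2 `CCOC(=O)CC1C(C(=O)OCC)=C(N)Oc2ccc(-c3ccccc3F)cc21`: 73000 nM
- Compound 3 `CCOC(=O)CC1C(C(=O)OCC)=C(N)Oc2ccc(-c3cccs3)cc21`: > 80000 nM, a limit and not a number

Compound 3 stands at the limit of > 80000 nM in this assay, at which 1 of the 3 values shown sits, so it has no exact place among the three. The next step leads to compound 4 `CCOC(=O)CC1C(C(=O)OCC)=C(N)Oc2ccc(-c3cccc(N)c3)cc21`: 3-aminophenyl in place of thiophen-2-yl on an aromatic carbon. This puts 3-aminophenyl in place of thiophen-2-yl on an aromatic carbon.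

For the measured compounds named here, only one measured step bears on this change, at the same place on the shared core. It is an at least 1.0-fold higher number from compound 2 to compound 3 (0.03 log units; that floor lies within the scatter), and its floor says little about true size. The closest numerical guide is compound 2, which carries 2-fluorophenyl and reads 73000 nM. Compound 4 also carries a phenyl group, so a value in that region of this assay is expected, and a reading at the limit remains possible.

The estimate means an at least 1.4-fold lower number from compound 3 to compound 4 (0.16 log units; that floor lies within the scatter), expected as a lower number if any change appears, with no step beyond the scatter expected.

Compound 4 is expected at 55000 nM, with an estimated range of 25000 nM to 100000 nM.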

Compound 4, half-maximal inhibitory concentration: 20200 nM
For compound 4 the middle estimate is 2.7-fold (0.44 log units) above the measured one; measured number below the stated range.
By their numbers in this assay, from the lowest: compounds 4 and 1 (each within the scatter of the next); then compound 2. At a limit, above all of these: compound 3.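

In this assay, the group on this aromatic carbon now gives steps beyond the scatter, with 3-aminophenyl as the entering group in both: an at least 3.9-fold lower number from compound 3 to compound 4 (0.59 log units; beyond the scatter) and a 3.6-fold lower number from compound 2 to compound 4 (0.56 log units; beyond the scatter). The earlier step, from 2-fluorophenyl to thiophen-2-yl, had only a floor within the scatter, and the step from thiophen-2-yl to 3-aminophenyl is also a floor. Compound 3 stands at a limit and not a number: the limit of > 80000 nM in this assay, at which 1 of the 4 values shown sits.

Going by these compounds, whether the step follows the amine or the six-membered aromatic ring alone stays open, and an unsubstituted phenyl, a hydroxyphenyl or an acetamidophenyl group at this place would help separate the two. Also open, on these data alone, is how 3-aminophenyl reads with the butyl esters of compound 1, which differs from the ethyl esters in more than one place.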